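The compounds below may be only part of what the source reports. "The series", "measured", "known", "first", "only" and "open" are said of these compounds alone.

Compound 1, with the structure `C=C1CCCC(C)(C)C1CC[C@]1(C)CC[C@@H]([C@@H](C)C(=O)O)OO1`, is an acid built on a six-membered peroxide ring that carries a methyl-bearing side chain. In a functional assay on UO-31 cells (Homo sapiens) for inhibition (a lower number here means a stronger inhibitor of growth, a higher number a weaker inhibitor of growth), compound 1 gives only a limit, > 10000 nM, so no number is known for it; this is the limit of > 10000 nM in this assay, at which 1 of the 3 values shown sits, the weak end of the three results shown. The methyl ester compound 2, `C=C1CCCC(C)(C)C1CC[C@]1(C)CC[C@H]([C@@H](C)C(=O)OC)OO1`, gives 520 nM in this assay. Compound 3, `C=C1CCC[C@H]2[C@](C)(CC[C@]3(C)CC[C@@H]([C@@H](C)C(=O)O)OO3)[C@@H](C)CC[C@]12C`, an acid with a larger fused core, gives 900 nM in this assay. Compound 4, `C=C1CCCC(C)(C)C1CC[C@@]1(C)CC[C@H]([C@@H](C)C(=O)O)OO1`, is the compound to be measured next. Compared with compound 1 the change is the two compounds have the same atoms and bonds; at least one stereo element is drawn with a configuration in one of them and without one in the other: 2 of 4 stereo elements differ; a stereocentre at a saturated ring carbon is drawn R in compound 1 and S in compound 4; a stereocentre at a saturated ring carbon is drawn S in compound 1 and R in compound 4. Nothing measured here tells how such a swap of two ring stereocentres shifts growth inhibition, so the direction of the step is open. Compound 1 sits at the limit > 10000 nM in this assay. The acid compound 3 reaches 900 nM in this assay. Taken together, a move toward measurable inhibition is plausible, and compound 4 is expected to give about 3000 nM, within a range from 500 nM to 20000 nM, an expected step of an at least 3.3-fold lower number from compound 1 to compound 4 (0.52 log units; beyond the scatter).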

Compound 4, concentration for 50% growth inhibition: 4310 nM
Compound 4: the middle estimate sits 1.4-fold (0.16 log units) below what was measured; the range from low to high includes it.
By their numbers in this assay, from the lowest: compounds 2 and 3 (each within the scatter of the next); then compound 4. At a limit, above all of these: compound 1.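

Swapping the drawn configuration at two saturated ring carbons, with all atoms and bonds unchanged, gives an at least 2.3-fold lower number from compound 1 to compound 4 (0.36 log units; beyond the scatter). Among these compounds, this shows that the arrangement at these two ring stereocentres matters in this assay, which the earlier compounds could not show, as no two of them differed in one place only. From the compounds shown here alone, compound 1 gives only a limit, > 10000 nM, so the full size of the step stays unknown because of this: the limit of > 10000 nM in this assay, at which 1 of the 4 values shown sits.

The compounds shown leave open whether one of the two stereocentres alone accounts for the step, and whether an amide in place of the carboxylic acid of compound 4 would change growth inhibition. The comparison also carries a caution in how the two structures are drawn: the fact that one of compounds 1 and 4 is drawn with a defined configuration and the other without, at the place where they differ.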